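Next amide substituent: compound 2 to compound 3

This account rests on a few compounds, and the source may have more. Where it says the series, first, only, none or still open, it means among the compounds named here.

In a functional assay on MCF7 cells (Homo sapiens) for cytotoxicity, read by sulforhodamine B assay, with a stated time of 72 h (a higher number here means a weaker inhibitor, a lower number a stronger inhibitor), compound 1 (`Cc1ccc(-c2cc(C(=O)Nc3ccncc3)nn2-c2ccc3ccccc3n2)cc1`) gives 15400 nM and compound 2 (`Cc1ccc(-c2cc(C(=O)Nc3ncc(Br)cc3Br)nn2-c2ccc3ccccc3n2)cc1`) gives 16900 nM. Among the compounds with values here, these two values lie within the scatter of each other, so compound 2 stands level with compound 1 on the only numbers available. Compound 3 (`Cc1ccc(-c2cc(C(=O)Nc3ccncc3Br)nn2-c2ccc3ccccc3n2)cc1`) keeps the shared core and carries 3-bromopyridin-4-yl in place of 3,5-dibromopyridin-2-yl on an amide-type nitrogen. Within the data shown here, one measured step bears on this change: a 1.1-fold higher number from compound 1 to compound 2 (0.04 log units; within the scatter). It exchanged the group at the same place and stayed within the scatter. With a single step as evidence, the expectation is weakly supported, and no change beyond the scatter is expected in this assay, in either direction. The estimated step is a 1.1-fold lower number from compound 2 to compound 3 (0.02 log units; within the scatter). The expected value for compound 3 is 16000 nM, with an estimated range from 7000 nM to 35000 nM.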

Compound 3, half-maximal inhibitory concentration: 11000 nM
Compound 3: the middle estimate sits 1.5-fold (0.16 log units) above what was measured; the range from low to high includes it.
By their numbers in this assay, from the lowest: compounds 3, 1 and 2 (each within the scatter of the next).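

In this assay, bromo in place of hydrogen on an aromatic carbon of the pyridin-4-yl group gives a 1.4-fold lower number from compound 1 to compound 3 (0.15 log units; within the scatter) and so, on this one pair, does not shift the number beyond the scatter. Exchanging 3,5-dibromopyridin-2-yl for 3-bromopyridin-4-yl on the amide-type nitrogen gives a 1.5-fold lower number from compound 2 to compound 3 (0.19 log units; within the scatter) and adds a second exchange of this group within the scatter, leaving compound 1, compound 2 and compound 3 level with one another. No measurement at hand accounts for this level picture.

As far as these compounds go, whether a group of another kind on the amide-type nitrogen, such as a carboxylic acid or an amine on a short chain, would move the number beyond the scatter remains open. Also open, from the compounds shown here alone, is whether the level picture holds on a core altered elsewhere.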